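The compounds below may be only part of what the source reports. "The series", "measured", "known", "first", "only" and "open" are said of these compounds alone.

Measured so far in a functional assay on MCF7 cells (Homo sapiens) for cytotoxicity, read by WST assay, with a stated time of 72 h; on this read-out higher numbers stand for weaker inhibition and lower numbers for stronger inhibition:
- compound 1 `COc1ccc2c(c1C)NC(=O)C2(c1ccc(O)cc1)C1CCCC1`: 1 nM
- compound 2 `COc1ccc2c(c1C)NC(=O)C2(c1ccc(O)cc1)C1CCCCC1`: 14 nM

Of these two, compound 2 has the higher number at 14 nM, which means weaker inhibition in this assay. The next compound to be read is compound 3 `COc1ccc2c(c1C)NC(=O)C2(c1ccc(O)cc1)C1CCCCCC1`. The change is cycloheptyl in place of cyclohexyl on a saturated ring carbon, with cycloheptyl in place of cyclohexyl on a saturated ring carbon, two ring bonds from the ring nitrogen.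

Among the compounds with values here, one measured step bears on this change. It also enlarges the saturated carbon ring at the same place, with cyclohexyl in place of cyclopentyl, and gives a 14-fold higher number from compound 1 to compound 2 (1.15 log units; beyond the scatter). That step is large and beyond the scatter, and it runs toward weaker inhibition. Within the data shown here, a single step does not establish a trend, and no seven-membered ring has yet been measured, so the direction is only a tentative expectation.

The expected change is a 2.9-fold higher number from compound 2 to compound 3 (0.46 log units; beyond the scatter), a further move toward weaker inhibition, estimated as smaller than the measured step. For compound 3 the estimated value is 40 nM, with an expected range of 12 nM to 130 nM.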

Compound 3, half-maximal inhibitory concentration: 4.7 nM
Compound 3: the middle estimate sits 8.5-fold (0.93 log units) above what was measured; the measured number lies below the stated range.
By their numbers in this assay, from the lowest: compound 1; then compound 3; then compound 2.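

In this assay the size of the saturated carbon ring at this position does not act in one direction: enlarging cyclohexyl to cycloheptyl gives a 3.0-fold lower number from compound 2 to compound 3 (0.47 log units; beyond the scatter), which runs against the earlier rise of a 14-fold higher number from compound 1 to compound 2 (1.15 log units; beyond the scatter), so that compound 2 with its cyclohexyl goes against any steady trend with ring size among these three compounds. The recovery is only partial, since cycloheptyl in place of cyclopentyl still gives a 4.7-fold higher number from compound 1 to compound 3 (0.67 log units; beyond the scatter), which leaves the cyclopentyl of compound 1 with the lowest number of the three and the seven-membered ring between the other two. Nothing in hand accounts for this up-and-down pattern across the three rings.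

Open, on these data alone, is how a cyclobutyl or cyclooctyl ring on this carbon would read, and whether an open chain such as pentyl, or a ring carrying an amine, would fall in with the carbon rings. Also open, as far as these compounds go, is whether the same order of the three rings would hold with the methoxy or the phenol hydroxyl of the shared core replaced.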